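A few compounds are considered here, and "the series" means these few. Any claim that something is new, unique, unknown or untested is made for them only; others in the source may bear on it.

Compound 1, `c1ccc(-c2ccc3c(NCCCNCc4ccco4)ccnc3c2)cc1`: compound 1 gives 237 10^-6 cm/s
Compound 2, `CC(C)CCc1ccc2c(NCCCNCc3ccco3)ccnc2c1`: compound 2 gives 23 10^-6 cm/s
Compound 3, `Fc1ccc(Cc2ccc3c(NCCCNCc4ccco4)ccnc3c2)c(Cl)c1`: compound 3 gives 23 10^-6 cm/s

These three compounds share one core and were all run in an ADME assay for permeability, using PAMPA, with a stated time of 30 min, at pH 7.4; a lower number here means that the compound crosses the layer more slowly, a higher number that the compound crosses the layer faster. Compound 3 sits at the bottom of the three numbers, level with compound 2: no change at the digits printed from compound 2 to compound 3 (within the scatter). Compound 1 stands far above both, as a 10-fold lower number from compound 1 to compound 2 (1.01 log units; beyond the scatter) and a 10-fold lower number from compound 1 to compound 3 (1.01 log units; beyond the scatter) show.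

The next compound is compound 4, `COc1ccc(-c2ccc3c(NCCCNCc4ccco4)ccnc3c2)cc1`. Set against compound 3, the change is 4-methoxyphenyl in place of 2-chloro-4-fluorobenzyl on an aromatic carbon.

Going by the values given here, two measured steps bear on this. The first, a 10-fold lower number from compound 1 to compound 3 (1.01 log units; beyond the scatter), shows that swapping a phenyl on that aromatic carbon for a 2-chloro-4-fluorobenzyl costs a large drop. The second, no change at the digits printed from compound 2 to compound 3 (within the scatter), shows that compound 2 and compound 3 cannot be told apart. Compound 4 carries a 4-methoxyphenyl on the same aromatic carbon, which resembles the phenyl of compound 1 far more than the benzyl of compound 3. The expected result in this assay is therefore a large rise, roughly undoing the earlier drop: a 7.0-fold higher number from compound 3 to compound 4 (0.84 log units; beyond the scatter). The estimate for compound 4 in this assay is 160 10^-6 cm/s, expected to fall between 55 10^-6 cm/s and 330 10^-6 cm/s.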

Compound 4, apparent permeability: 237 10^-6 cm/s
Estimate against measurement, compound 4: 1.5-fold (0.17 log units) below; the range from low to high includes it.
By their numbers in this assay, from the lowest: compounds 2 and 3 (each within the scatter of the next); then compounds 1 and 4 (each within the scatter of the next).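

Placing a methoxy group on the phenyl ring gives no change at the digits printed from compound 1 to compound 4 (within the scatter) in this assay, so at this position the 4-methoxyphenyl of compound 4 and the plain phenyl of compound 1 cannot be told apart. Going by these compounds alone, the other two steps, a 10-fold higher number from compound 3 to compound 4 (1.01 log units; beyond the scatter) and a 10-fold higher number from compound 2 to compound 4 (1.01 log units; beyond the scatter), show that the large gap seen around compound 1 is not peculiar to that one compound: among the four compounds, the two with a phenyl ring bonded directly to the core sit together at the high end, while those with 2-chloro-4-fluorobenzyl or isopentyl sit together at the low end, and no compound goes against this split. Nothing available gives a reason for this split.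

Compound 3 differs from compound 1 both in the carbon link to its ring and in its chlorine and fluorine, so a plain benzyl group would be needed to show which of these goes with the lower number. Going by these compounds, it also remains open whether the high number would hold with an amine or a carboxylic acid in place of the methoxy group on the phenyl ring.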